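This account rests on a few compounds, and the source may have more. Where it says the series, first, only, none or still open, it means among the compounds named here.

In a functional assay on ECa-109 cells (Homo sapiens) for antiproliferative activity, read by MTT assay, with a stated time of 72 h (on this read-out lower numbers stand for stronger inhibition and higher numbers for weaker inhibition), compound 1 `CCCSc1nc(N/N=C/c2cccnc2)c2nnn(Cc3ccccc3)c2n1` gives > 64000 nM, which is a limit of the assay and not a number. That places it at the limit of > 64000 nM in this assay, at which 1 of the 3 values shown sits. By contrast, compound 2 `C#CCSc1nc(N/N=C/c2cc(OC)c(OC)c(OC)c2)c2nnn(Cc3ccccc3)c2n1` gives 6540 nM, and compound 3 `CCCSc1nc(N/N=C(\C)c2ccccc2O)c2nnn(Cc3ccccc3)c2n1` gives 11100 nM. Compound 4 `CCCSc1nc(N/N=C/c2ccc(N(C)C)cc2)c2nnn(Cc3ccccc3)c2n1` has not yet been measured, and its difference from compound 1 is 4-(dimethylamino)phenyl in place of pyridin-3-yl on a carbon with a double bond to nitrogen. Going by the values given here, the one measured step that bears on this is an at least 5.7-fold lower number from compound 1 to compound 3 (0.76 log units; beyond the scatter), which also exchanges the pyridin-3-yl for a six-membered aromatic ring of carbon only. A step of similar size toward a lower number is therefore expected in this assay, an at least 4.2-fold lower number from compound 1 to compound 4 (0.63 log units; beyond the scatter). Compound 4 is estimated at 15000 nM, with an expected range from 4000 nM to 55000 nM.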

Compound 4, half-maximal inhibitory concentration: 20000 nM
Beside the measured number, compound 4's estimate is 1.3-fold (0.12 log units) below it, and the stated range covers the measured number.
By their numbers in this assay, from the lowest: compounds 2, 3 and 4 (each within the scatter of the next, the first and the last beyond it). At a limit, above all of these: compound 1.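

In this assay, exchanging only the ring group, 4-(dimethylamino)phenyl in place of pyridin-3-yl on a carbon with a double bond to nitrogen, gives an at least 3.2-fold lower number from compound 1 to compound 4 (0.50 log units; beyond the scatter). Compound 3 changed more than the ring group, whereas compound 4 isolates this exchange and still shows a step beyond the scatter. Compound 1 stands at a limit, so the full size of the step stays unknown: the limit of > 64000 nM in this assay, at which 1 of the 4 values shown sits.

The compounds shown leave open whether the dimethylamino group is needed, or whether a plain phenyl would give a similar number. From the compounds shown here alone, how a carboxylic acid on this ring would read also stays open.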